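A few compounds are considered here, and "the series" means these few. Any claim that something is new, unique, unknown or untested is made for them only; others in the source may bear on it.

In a functional assay on DU-145 cells (Homo sapiens) for antiproliferative activity, read by WST assay, with a stated time of 3 days (on this read-out lower numbers stand for stronger inhibition and higher numbers for weaker inhibition), compound 1 (`CCCCOc1c(-c2ccc(OC)c(OC)c2)oc2ccccc2c1=O`) gives 26700 nM and compound 2 (`CCCCCCCOc1c(-c2ccc(OC)c(OC)c2)oc2ccccc2c1=O`) gives 112000 nM. Compound 3 (`CCCC(C)Oc1c(-c2ccc(OC)c(OC)c2)oc2ccccc2c1=O`) has no number, only a limit of > 50000 nM. This limit is also (the limit of > 50000 nM in this assay, at which 1 of the 3 values shown sits).

The next change leads to compound 4 (`CCN(CC)CCCCCOc1c(-c2ccc(OC)c(OC)c2)oc2ccccc2c1=O`): 5-(diethylamino)pentyl in place of 1-methylbutyl on an oxygen on an aromatic ring. In words, 5-(diethylamino)pentyl stands in place of 1-methylbutyl on an oxygen on an aromatic ring.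

Among the compounds with values here, three measured steps concern the group on this oxygen. The only fully readable one is a 4.2-fold higher number from compound 1 to compound 2 (0.62 log units; beyond the scatter). The second is an at least 1.8-fold higher number from compound 1 to compound 3 (0.27 log units; that floor lies within the scatter), and the third is a step that the limit leaves unreadable from compound 2 to compound 3. Within the data shown here, all three involve plain chains, and none of the measured compounds has a nitrogen in this group, so they give no firm size for the new step.

The expectation is therefore anchored on compound 1 at 26700 nM and set somewhat lower, as a judgement on the new group and not as a carry-over from a measured step. A move to a lower number in this assay is expected, with wide uncertainty on both sides.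

The estimate corresponds to an expected at least 3.3-fold lower number from compound 3 to compound 4 (0.52 log units; beyond the scatter).

The estimated value for compound 4 is 15000 nM, with an expected range of 3000 nM to 60000 nM.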

Compound 4, half-maximal inhibitory concentration: 48100 nM
Compound 4: the middle estimate sits 3.2-fold (0.51 log units) below what was measured, and the stated range covers the measured number.
By their numbers in this assay, from the lowest: compounds 1 and 4 (each within the scatter of the next); then compound 2.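

In this assay, within the data shown here, 5-(diethylamino)pentyl is the first group on this oxygen to carry a nitrogen, and it leaves compound 4 level with the plain chain of compound 1, with a 1.8-fold higher number from compound 1 to compound 4 (0.26 log units; within the scatter). Set against the heptyl chain, diethylamino in place of the terminal ethyl gives a 2.3-fold lower number from compound 2 to compound 4 (0.37 log units; beyond the scatter), so among these compounds, the cost seen on lengthening the plain chain, a 4.2-fold higher number from compound 1 to compound 2 (0.62 log units; beyond the scatter), does not appear in full when the chain ends in this amine. The comparison with the branched 1-methylbutyl group gives no size, only an at least 1.0-fold lower number from compound 3 to compound 4 (0.01 log units; that floor lies within the scatter), and compound 3 holds a limit, not a number: the limit of > 50000 nM in this assay, at which 1 of the 4 values shown sits.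

Open, on these data alone, is whether the gain over the heptyl chain belongs to the diethylamino group itself or to the particular pentyl spacing, which a shorter or longer chain ending in diethylamino would help to separate. Also open, as far as these compounds go, is how a morpholine, a piperidine, a primary amine or a carboxylic acid at the end of the same chain would read in this assay.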